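The compounds below may be only part of what the source reports. "The series", "measured", "known", "first", "only" and "open" are said of these compounds alone.

Values in a functional assay on K562 cells (Homo sapiens) for cytotoxicity, read by MTT assay, with a stated time of 3 days (on this read-out higher numbers stand for weaker inhibition and lower numbers for stronger inhibition), for the measured members of the series:

compound 1, `N#Cc1c(NN)nc(SCc2nc3ccccc3[nH]2)nc1-c1ccccc1`: 14.7 nM
compound 2, `CNc1nc(SCc2nc3ccccc3[nH]2)nc(-c2ccccc2)c1C#N`: 13.2 nM
compound 3, `N#Cc1c(Nc2ccccn2)nc(SCc2nc3ccccc3[nH]2)nc1-c1ccccc1`: 7 nM

Compound 3 gives the lowest of the three numbers. For the measured compounds named here, the step of a 1.9-fold lower number from compound 2 to compound 3 (0.28 log units; within the scatter) lies within the scatter, so compounds 2 and 3 cannot be separated on these data; only the step of a 2.1-fold lower number from compound 1 to compound 3 (0.32 log units; beyond the scatter) is beyond it, and modestly so.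

Compound 4, `N#Cc1c(NC(N)=O)nc(SCc2nc3ccccc3[nH]2)nc1-c1ccccc1`, has not yet been measured. It differs from compound 3 in one place: carbamoyl in place of pyridin-2-yl on a nitrogen on an aromatic ring.

The three measured steps all concern this same position. Exchanging amino for methyl, a 1.1-fold lower number from compound 1 to compound 2 (0.05 log units; within the scatter), made no difference beyond the scatter, while exchanging either of these small groups for pyridin-2-yl gave a 2.1-fold lower number from compound 1 to compound 3 (0.32 log units; beyond the scatter) and a 1.9-fold lower number from compound 2 to compound 3 (0.28 log units; within the scatter), both small. Carbamoyl is again a small group without a ring, so the change from compound 3 to compound 4 is expected to roughly reverse the small gain seen on going to pyridin-2-yl, giving a modest upward step of about a 1.7-fold higher number from compound 3 to compound 4 (0.23 log units; within the scatter) in this assay, with a result within the scatter of compound 3 also possible.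

For compound 4 the expected value in this assay is 12 nM, with a range of 5 nM to 30 nM.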

Compound 4, half-maximal inhibitory concentration: 4.54 nM
Estimate against measurement, compound 4: 2.6-fold (0.42 log units) above; the measured number lies below the stated range.
By their numbers in this assay, from the lowest: compounds 4, 3, 2 and 1 (each within the scatter of the next, the first and the last beyond it).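

With a 1.5-fold lower number from compound 3 to compound 4 (0.19 log units; within the scatter) in this assay carbamoyl and pyridin-2-yl on this nitrogen cannot be separated, so a ring at this position is not required for a number at the level of compound 3. The groups without a ring also do not behave as one set: carbamoyl stands apart from methyl with a 2.9-fold lower number from compound 2 to compound 4 (0.46 log units; beyond the scatter) and from amino with a 3.2-fold lower number from compound 1 to compound 4 (0.51 log units; beyond the scatter) and both of these modest steps lie beyond the scatter, whereas amino and methyl could not be separated from each other. No measurement at hand accounts for what sets carbamoyl apart from amino and methyl.

Still open, from the compounds shown here alone, is whether acetyl, which keeps the carbonyl without the amino part of carbamoyl, or methylcarbamoyl, which extends it, would stay with compound 4 or return to the level of compound 2. The compounds shown also leave open whether the same ordering of groups holds when other parts of the shared core change, since all four differ only on this one nitrogen.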